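A few compounds are considered here, and "the series" means these few. Any claim that something is new, unique, unknown or untested is made for them only; others in the source may bear on it.

Working notes on the series. Compound 1 `Cc1ccc(CC2CCN(c3nc(C(F)(F)F)ccc3CNC(=O)C(C)c3ccc(NS(C)(=O)=O)c(F)c3)CC2)cc1` gives 17 nM in a functional assay on CHO-K1 cells for antagonist activity at transient receptor potential cation channel subfamily V member 1 (Homo sapiens), read by FLIPR; on this read-out higher numbers stand for weaker inhibition and lower numbers for stronger inhibition. Compound 2 `CC(C(=O)NCc1ccc(C(F)(F)F)nc1N1CCC(C(F)(F)F)CC1)c1ccc(NS(C)(=O)=O)c(F)c1` gives 31 nM in this assay. Going by the values given here, compound 2 stands highest of the two numbers so far, yet its one neighbour is compound 1, and the step of a 1.8-fold higher number from compound 1 to compound 2 (0.26 log units; within the scatter) shows that the two values cannot be told apart on this read-out.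

Compound 3 `CC(C(=O)NCc1ccc(C(F)(F)F)nc1N1CCC(OC(=O)C(C)(C)C)CC1)c1ccc(NS(C)(=O)=O)c(F)c1` is not yet measured. The change from compound 2 is ((tert-butyl)carbonyl)oxy in place of trifluoromethyl on a saturated ring carbon, three ring bonds from the ring nitrogen. Among the compounds with values here, the only step that bears on this position is the one from compound 1 to compound 2, where a large group was exchanged for trifluoromethyl and the number moved by a 1.8-fold higher number from compound 1 to compound 2 (0.26 log units; within the scatter), within the scatter. That single step is thin evidence, but it is the only pointer, and it shows no movement at this position. Compound 3 is therefore expected to give 35 nM in this assay, between 12 nM and 110 nM, with the step of a 1.1-fold higher number from compound 2 to compound 3 (0.05 log units; within the scatter) expected to stay within the scatter, in no clear direction.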

Compound 3, half-maximal inhibitory concentration: 45.2 nM
Beside the measured number, compound 3's estimate is 1.3-fold (0.11 log units) below it; low and high end bracket the measured number.
By their numbers in this assay, from the lowest: compounds 1, 2 and 3 (each within the scatter of the next, the first and the last beyond it).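

At this saturated ring carbon in this assay, ((tert-butyl)carbonyl)oxy, with its 2 hydrogen-bond acceptors and 7 heavy atoms, takes the place of trifluoromethyl, which has no hydrogen-bond acceptors and 4 heavy atoms, and the result (a 1.5-fold higher number from compound 2 to compound 3 (0.16 log units; within the scatter)) cannot be told apart from no change. The exchange for 4-methylbenzyl (a 2.7-fold higher number from compound 1 to compound 3 (0.42 log units; beyond the scatter)) is the first step at this position to pass the scatter, so the position is no longer flat across every group shown, although the step is modest and compound 2 lies within the scatter of both other compounds. Nothing available accounts for this modest step.

Still open, as far as these compounds go, is how a hydroxyl, a primary amine or a carboxylic acid on this ring carbon would read out, as would a group with a hydrogen-bond donor in general. Also open, from the compounds shown here alone, is whether a plain tert-butyl or a longer alkyl chain, which lacks the carbonyl and the oxygen of ((tert-butyl)carbonyl)oxy, would stay with compound 2 and compound 3 or with compound 1.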